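The compounds below may be only part of what the source reports. "The series", "measured", "known", "first", "only" and "open" are said of these compounds alone.

Three compounds have been measured in a functional assay on BJAB cells (Homo sapiens) for antiproliferative activity, with a stated time of 4 days; a higher number here means that more compound is needed for the effect, a lower number that less compound is needed:
compound 1 `Cc1nn(-c2nc(-c3ccc(Cl)c(Cl)c3)c(SC(C)C)s2)c(C(=O)O)c1-c1cccc(Cl)c1C` gives 5100 nM;
compound 2 `Cc1nn(-c2nc(-c3ccc(Cl)c(Cl)c3)c(SC(C)C)s2)c(C(=O)O)c1-c1cnn(C)c1` gives 6800 nM;
compound 3 `Cc1nn(-c2nc(-c3ccc(Cl)c(Cl)c3)c(SC(C)C)s2)c(C(=O)O)c1-c1ccccc1Cl` gives 13100 nM.

Compound 1 stands at the lowest number of the three; compound 2 sits within the scatter of it, while compound 3 shows a 2.6-fold higher number from compound 1 to compound 3 (0.41 log units; beyond the scatter). Compound 4 `CNc1cc(-c2c(C)nn(-c3nc(-c4ccc(Cl)c(Cl)c4)c(SC(C)C)s3)c2C(=O)O)ccn1` differs from compound 1 in one place: 2-(methylamino)pyridin-4-yl in place of 3-chloro-2-methylphenyl on an aromatic carbon. For the measured compounds named here, two measured steps touch this same position: the swap to 1-methyl-1H-pyrazol-4-yl, a 1.3-fold higher number from compound 1 to compound 2 (0.12 log units; within the scatter), and the swap to 2-chlorophenyl, a 2.6-fold higher number from compound 1 to compound 3 (0.41 log units; beyond the scatter). Both raise the number, one within the scatter and one modestly beyond it. On these data alone, no measured group here carries a hydrogen-bond donor, so the entering group is untested. A small rise or no step beyond the scatter is expected, a 1.3-fold higher number from compound 1 to compound 4 (0.11 log units; within the scatter). Compound 4 is therefore estimated at 6500 nM, with a likely range from 2500 nM to 16000 nM.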

Compound 4, half-maximal effective concentration: 18000 nM
Compound 4: middle estimate off by 2.8-fold (0.44 log units), on the low side; measured number above the stated range.
By their numbers in this assay, from the lowest: compounds 1, 2, 3 and 4 (each within the scatter of the next, the first and the last beyond it).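

For the compounds shown here, the first group at this position with a hydrogen-bond donor, 2-(methylamino)pyridin-4-yl, raises the number in this assay (a 3.5-fold higher number from compound 1 to compound 4 (0.55 log units; beyond the scatter)) and also relative to 1-methyl-1H-pyrazol-4-yl (a 2.6-fold higher number from compound 2 to compound 4 (0.42 log units; beyond the scatter)), while it stays level with 2-chlorophenyl (a 1.4-fold higher number from compound 3 to compound 4 (0.14 log units; within the scatter)). So none of the three swaps at this position lowers the number from compound 1. The data shown give no evidence on why this step occurs.

On these data alone, whether the methylamino group or the pyridine ring nitrogen goes with this rise remains open. A plain pyridin-4-yl or a 3-aminophenyl group would help separate the two.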